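The compounds below may be only part of what the source reports. "The series", "measured", "known", "first", "only" and "open" are said of these compounds alone.

Compound 1 `Cc1cc(S(N)(=O)=O)ccc1NC(=O)COc1ccc(F)cc1Oc1ccc2ccccc2c1C` and compound 2 `Cc1cc(S(N)(=O)=O)ccc1NC(=O)COc1ccc(F)cc1Oc1ccc2ccccc2c1Br` share a core and differ only at one aromatic carbon of the naphthalene-bearing end. In an ADME assay on C8166 cells (Homo sapiens) for cytotoxicity, read by MTT assay (on this read-out lower numbers stand for higher toxicity in this test and higher numbers for lower toxicity in this test), compound 1 gives 56100 nM, and compound 2 gives 39500 nM. The step of a 1.4-fold lower number from compound 1 to compound 2 (0.15 log units; within the scatter) is small, and compound 2 therefore stands alongside compound 1 rather than apart from it: its number is the lower of the two, yet the gap is within the scatter.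

Compound 3 `Cc1cc(S(N)(=O)=O)ccc1NC(=O)COc1ccc(F)cc1Oc1c(C)cc2ccccc2c1Cl` is the unmeasured member. It differs from compound 2 by 1-chloro-3-methylnaphthalen-2-yl in place of 1-bromonaphthalen-2-yl on an oxygen on an aromatic ring. Among the measured compounds shown here, the only measured step bearing on this position is a 1.4-fold lower number from compound 1 to compound 2 (0.15 log units; within the scatter), which exchanges one halogen-sized group for another and stays within the scatter; no measured step covers the added methyl. On that basis no change beyond the scatter is expected, with a 1.1-fold higher number from compound 2 to compound 3 (0.06 log units; within the scatter) as the expected step. Compound 3 is estimated at 45000 nM in this assay, with a range from 20000 nM to 100000 nM.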

Compound 3, half-maximal cytotoxic concentration: 55600 nM
For compound 3 the middle estimate is 1.2-fold (0.09 log units) below the measured one, within the range that was stated.
By their numbers in this assay, from the lowest: compounds 2, 3 and 1 (each within the scatter of the next).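

In this assay, the naphthalene-bearing end on this oxygen now shows no shift beyond the scatter even for a change larger than the earlier single exchange: 1-chloro-3-methylnaphthalen-2-yl in place of 1-bromonaphthalen-2-yl gives (a 1.4-fold higher number from compound 2 to compound 3 (0.15 log units; within the scatter)), and in place of 1-methylnaphthalen-2-yl it gives (a 1.0-fold lower number from compound 1 to compound 3 (0.00 log units; within the scatter)). The three compounds therefore read alike in this test, even with one more heavy atom in the group that enters. Nothing available here accounts for this reading.

As far as these compounds go, the chloro and the added methyl enter together in compound 3, so what each does alone remains open. Also open, from the compounds shown here alone, is whether an amine or a carboxylic acid on the naphthalene would stay within the scatter of these three compounds.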